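This account rests on a few compounds, and the source may have more. Where it says the series, first, only, none or still open, it means among the compounds named here.

Values in a functional assay on DU-145 cells (Homo sapiens) for cytotoxicity, read by ELISA, with a stated time of 4 days; a higher number here means a weaker inhibitor, a lower number a stronger inhibitor:
- compound 1 `Cc1ccccc1-c1cc(-c2ccoc2)cc(-c2ccc(Cl)s2)n1`: 18500 nM
- compound 2 `Cc1ccc(-c2cc(-c3ccoc3)cc(-c3ccc(Cl)s3)n2)cc1`: 25300 nM
- compound 3 `Clc1ccc(-c2cc(-c3ccoc3)cc(-c3ccc(Cl)s3)n2)cc1`: 29500 nM

Compound 3 cannot be separated from the other two compounds on these numbers. Its steps are a 1.6-fold higher number from compound 1 to compound 3 (0.20 log units; within the scatter) and a 1.2-fold higher number from compound 2 to compound 3 (0.07 log units; within the scatter), and the remaining pair shows a 1.4-fold higher number from compound 1 to compound 2 (0.14 log units; within the scatter). All three values therefore form a single group within the scatter.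

The next compound is compound 4 `Clc1ccc(-c2cc(-c3ccoc3)cc(-c3ccccn3)n2)s1`, which has not yet been measured. The structural change is pyridin-2-yl in place of 4-chlorophenyl on an aromatic carbon, in words pyridin-2-yl in place of 4-chlorophenyl on an aromatic carbon.

All three measured steps bear on this change, since each alters the group at this same place. None of them moves the number beyond the scatter. Among the compounds with values here, they cover only substituted phenyl groups, however, and no measured compound carries pyridin-2-yl at this place, so the precedent is indirect. No step beyond the scatter is therefore expected in this assay, and the data set no firm direction.

The expected step is a 1.5-fold lower number from compound 3 to compound 4 (0.17 log units; within the scatter). For compound 4 the estimated value is 20000 nM, with an expected range from 7000 nM to 50000 nM.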

Compound 4, half-maximal inhibitory concentration: 20500 nM
The estimate for compound 4 lay 1.0-fold (0.01 log units) below the measured number; the measured number falls inside the stated range.
By their numbers in this assay, from the lowest: compounds 1, 4, 2 and 3 (each within the scatter of the next).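

In this assay, within the data shown here, pyridin-2-yl is the only group at this place with a ring nitrogen and a hydrogen-bond acceptor, yet it stays within the scatter of all three compounds with a phenyl group there: a 1.4-fold lower number from compound 3 to compound 4 (0.16 log units; within the scatter), a 1.2-fold lower number from compound 2 to compound 4 (0.09 log units; within the scatter) and a 1.1-fold higher number from compound 1 to compound 4 (0.04 log units; within the scatter). Among these compounds, the earlier compounds covered only six-membered aromatic rings of carbon only, whereas this result extends the single group of values to a six-membered aromatic ring with 1 hetero atom on the same aromatic carbon next to the ring nitrogen, so all four compounds remain inseparable in this assay. Nothing at hand accounts for this flat reading.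

On these data alone, whether a piperidine or other saturated amine, a carboxylic acid or a longer alkyl chain at this place would move the number beyond the scatter stays open. The furan-3-yl and 5-chlorothiophen-2-yl groups are the same in all four compounds, so these values say nothing about what either group contributes to the cytotoxic reading.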